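Phenoxy replaces dichlorophenyl on the shared pyrimidine-free core

The source may report more compounds than this note shows. Statements on the series, on what has been measured and on what is new or still open speak of the compounds shown alone.

Measured so far:
compound 1 `CCOC(=O)c1cnc(C2CC2)nc1NN1C(=O)C=C(C)C1=O` gives 1000 nM in a functional assay on Jurkat cells for inhibition of nuclear factor NF-kappa-B complex (Homo sapiens); a lower number here means a stronger inhibitor, a higher number a weaker inhibitor
compound 2 `CCOC(=O)c1cnc(-c2cc(Cl)cc(Cl)c2)nc1NN1C(=O)C=C(C)C1=O` gives 300 nM in this assay

Among the two numbers measured so far, compound 2 stands lowest; its nearest neighbour is compound 1, separated by a 3.3-fold lower number from compound 1 to compound 2 (0.52 log units; beyond the scatter). Among the measured compounds shown here, that single step, 3,5-dichlorophenyl in place of cyclopropyl on an aromatic carbon, is the only one recorded on this core.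

Compound 3 `CCOC(=O)c1cnc(Oc2ccccc2)nc1NN1C(=O)C=C(C)C1=O` is not yet measured. It differs from compound 2 by phenoxy in place of 3,5-dichlorophenyl on an aromatic carbon. For the measured compounds named here, the only step that bears on this change is the one from compound 1 to compound 2, which shows that putting a six-membered aromatic ring of carbon at this place gave a modest drop in the number. Going by the values given here, compound 3 keeps such a ring but loses both chlorines and gains a hydrogen-bond acceptor through the phenoxy linkage; no measured pair speaks to that exchange. A step in either direction of modest size, or none beyond the scatter, is therefore possible; the expectation leans toward a somewhat higher number, a 2.0-fold higher number from compound 2 to compound 3 (0.30 log units; within the scatter). Compound 3 is thus expected to give about 600 nM, within a range of 200 nM to 2000 nM.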

Compound 3, half-maximal inhibitory concentration: 15000 nM
Beside the measured number, compound 3's estimate is 25-fold (1.40 log units) below it, and the stated range ends below it.
By their numbers in this assay, from the lowest: compound 2; then compound 1; then compound 3.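

In this assay, the aromatic carbon between two ring nitrogen atoms proves far less forgiving than the first pair suggested: phenoxy in place of 3,5-dichlorophenyl gives a 50-fold higher number from compound 2 to compound 3 (1.70 log units; beyond the scatter) and turns the best of the three into the poorest. Phenoxy also falls well behind the much smaller cyclopropyl, with a 15-fold higher number from compound 1 to compound 3 (1.18 log units; beyond the scatter), so a six-membered aromatic ring of carbon at this place does not by itself set the number: compound 2 and compound 3 both carry one, while compound 1 has none and still gives a lower number than compound 3. No measurement offered here accounts for the size of this change.

The exchange does two things at once, removing both chlorines and bringing in the oxygen linkage, and the compounds shown cannot say which of these carries the rise, as neither plain phenyl nor 3,5-dichlorophenoxy stands among them. Also open, from the compounds shown here alone, is how an amine or a longer alkyl chain would read at this place in this assay.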